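The compounds below may be only part of what the source reports. "The series", "measured", "known", "first", "only" and "open" are said of these compounds alone.

Measured in a functional assay on MKN-45 cells (Homo sapiens) for cytotoxicity, read by MTT assay, with a stated time of 72 h; a higher number here means a weaker inhibitor, a lower number a stronger inhibitor:
compound 1, `COc1ccc(-c2cc(C(=O)Nc3ccc(Oc4ccnc5cc(OCCCN6CCCCC6)c(OC)cc45)c(F)c3)c3ccccc3n2)cc1`: 210 nM
compound 2, `COc1cc2c(Oc3ccc(NC(=O)c4cc(-c5ccc(F)cc5)nc5ccccc45)cc3F)ccnc2cc1OCCCN1CCCCC1`: 28 nM

For the measured compounds named here, compound 2 holds the lower of the two numbers so far in this assay; its only neighbour is compound 1, and the single measured step, a 7.5-fold lower number from compound 1 to compound 2 (0.88 log units; beyond the scatter), lies beyond the scatter.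

Compound 3, `COc1cc2c(Oc3ccc(NC(=O)c4cc(-c5cccc(Cl)c5)nc5ccccc45)cc3F)ccnc2cc1OCCCN1CCCCC1`, is the next member and differs from compound 2 in one place: 3-chlorophenyl in place of 4-fluorophenyl on an aromatic carbon. Going by the values given here, no measured step bears directly on this change. Among the compounds with values here, the one step available, a 7.5-fold lower number from compound 1 to compound 2 (0.88 log units; beyond the scatter), concerns fluoro in place of methoxy, not the exchange of one halogenated phenyl for another, so it gives neither a direction nor a size for the present swap. The working expectation is therefore a small step, a 1.3-fold higher number from compound 2 to compound 3 (0.10 log units; within the scatter), that could fall within the scatter in either direction, with the wider range reflecting the absence of a bearing step. Compound 3 is estimated at 35 nM in this assay, with a range from 12 nM to 110 nM.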

Compound 3, half-maximal inhibitory concentration: 11 nM
Compound 3: the middle estimate sits 3.2-fold (0.50 log units) above what was measured; measured number below the stated range.
By their numbers in this assay, from the lowest: compound 3; then compound 2; then compound 1.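

In this assay, the position next to the ring nitrogen does not treat all halogenated phenyl groups alike: 3-chlorophenyl in place of 4-fluorophenyl gives a 2.5-fold lower number from compound 2 to compound 3 (0.41 log units; beyond the scatter). Measured against 4-methoxyphenyl, the same group gives a 19-fold lower number from compound 1 to compound 3 (1.28 log units; beyond the scatter), so the three compounds, which differ only at this position, now form an order with each step beyond the scatter, and the earlier 7.5-fold lower number from compound 1 to compound 2 (0.88 log units; beyond the scatter) no longer marks the end of the range at this position. No measurement at hand offers an explanation for this order.

Compound 2 and compound 3 differ both in the halogen and in where it sits on the phenyl ring, so the compounds shown cannot assign the step to either change; a chlorophenyl carrying its chlorine where compound 2 carries its fluorine would separate the two. Also open, as far as these compounds go, is whether the order extends beyond halogens at this position, for example to a phenyl ring bearing an amine or a carboxylic acid, or to a longer chain in place of the phenyl ring.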